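A few compounds are considered here, and "the series" means these few. Any claim that something is new, unique, unknown or untested is made for them only; others in the source may bear on it.

Measured so far:
compound 1, `CC(C)C[C@H](N)c1cc(C(F)(F)F)ccc1N1CCN(C(=O)CCc2cccc(C(F)(F)F)c2)CC1`: 2200 nM
compound 2, `CCN[C@H](c1cc(C(F)(F)F)ccc1N1CCN(C(=O)CCc2ccc(Cl)cc2Cl)CC1)C(C)CC`: 92 nM

In an assay on HEK293 cells for displacement of a labelled ligand from Melanocortin receptor 4 (Homo sapiens) (on this read-out higher numbers stand for weaker inhibition and lower numbers for stronger inhibition), compound 2 gives 92 nM, the lower of the two numbers. Compound 1 gives 2200 nM in this assay, and the gap between the two lies beyond the scatter. Compound 1 and compound 2 differ in more than one place, so their two values show only a combined outcome; no single change can be read from them.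

Compound 3, `CCN[C@@H](CC(C)C)c1cc(C(F)(F)F)ccc1N1CCN(C(=O)CCc2ccc(Cl)cc2Cl)CC1`, is not yet measured. It keeps the core of compound 2 and differs from it by isobutyl in place of sec-butyl on a saturated chain carbon bound to an amine nitrogen and an aromatic carbon; the same atoms are joined differently. Among the measured compounds shown here, no step between measured compounds isolates a rearrangement of this kind, so its size is unknown from the data. The expected step of a 1.6-fold higher number from compound 2 to compound 3 (0.21 log units; within the scatter) is small, within or near the scatter, with a slight lean toward a higher number. Compound 3 is expected to give about 150 nM in this assay, with a range from 50 nM to 500 nM.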

Compound 3, inhibition constant: 170 nM
Compound 3: the middle estimate sits 1.1-fold (0.05 log units) below what was measured, and the stated range covers the measured number.
By their numbers in this assay, from the lowest: compounds 2 and 3 (each within the scatter of the next); then compound 1.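

In this assay, among the compounds shown here, this is the first one-place comparison, and it shows that isobutyl in place of sec-butyl on a saturated chain carbon bound to an amine nitrogen and an aromatic carbon gives a 1.8-fold higher number from compound 2 to compound 3 (0.27 log units; within the scatter). At this position, with the rest of compound 2 kept, the two branched groups are therefore not told apart by this read-out. No measured evidence offers an account of this result.

Compound 1 also carries isobutyl but differs from compound 3 in more than one place, so the origin of its separate value stays unassigned. Also open, as far as these compounds go, is whether a group of another shape at this carbon, such as cyclohexyl or a straight n-propyl chain, would stay within the scatter of compound 2 and compound 3.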